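A few compounds are considered here, and "the series" means these few. Any claim that something is new, unique, unknown or untested is made for them only; others in the source may bear on it.

Compound 2 `Cc1ccc(NC(=O)C(=O)NC(c2nc(C)c(CO)s2)C2CCCCN2)cc1F` is one of three compounds whose tolerance has been read in an ADME assay on TZM-b1 cells (Homo sapiens) for cytotoxicity, read by XTT assay, with a stated time of 3 days; a higher number here means that more compound is tolerated, a lower number that less compound is tolerated. In this assay compound 2 gives > 88000 nM, which is a limit of the assay and not a number. Compound 1 `Cc1ccc(NC(=O)C(=O)NC(c2nc(C)c(CCO)s2)C2CCCCN2)cc1F` also reaches only a limit in this assay, giving > 85000 nM. Compound 3 `Cc1nc(C(NC(=O)C(=O)Nc2ccc(F)cc2F)C2CCCCN2)sc1CCO` likewise gives a limit in this assay, > 84000 nM. All three values sit at a limit, as seen in the limit of > 84000 nM in this assay, at which 1 of the 3 values shown sits, the limit of > 85000 nM in this assay, at which 1 of the 3 values shown sits, and (the limit of > 88000 nM in this assay, at which 1 of the 3 values shown sits), so compound 2 stands level with its neighbours as far as the numbers can tell.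

Compound 4 `Cc1nc(C(NC(=O)C(=O)NC2CCCCCC2)C2CCCCN2)sc1CO` has not yet been measured; it differs from compound 2 by cycloheptyl in place of 3-fluoro-4-methylphenyl on an amide-type nitrogen. Among the compounds with values here, two measured steps touch the same region: a step that the two limits leave unreadable from compound 1 to compound 2, on the other end of the shared core, and a step that the two limits leave unreadable from compound 1 to compound 3, on the same amide-type nitrogen. Neither yields a readable size, so no direction can be taken from them. The step from compound 2 to compound 4 is therefore expected as an at least 1.1-fold lower number from compound 2 to compound 4 (0.04 log units; that floor lies within the scatter), none beyond the scatter. Compound 4 is estimated in this assay at 80000 nM, in the range 40000 nM to 150000 nM.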

Compound 4, half-maximal cytotoxic concentration: > 90000 nM
Compound 4 gave a limit, no number; the forecaster's own chance of this, stated with the estimate: 75%; at least 1.1-fold (0.05 log units) between middle value and limit.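

Compound 4, like compound 2, reaches only a limit in this assay, so the step between compound 2 and compound 4 cannot be read. The compounds shown leave open what concentration any of the four tolerates, and whether cycloheptyl and 3-fluoro-4-methylphenyl differ here at all.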